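Shifting halogens on the hydrazone aryl ring

This account rests on a few compounds, and the source may have more. Where it says the series, first, only, none or still open, it means among the compounds named here.

The series shares one core, carried by compound 1 `CN(C)CCn1cnnc1-c1cc(Oc2ccc(NC(=O)N/N=C/c3c(Cl)cccc3Cl)cc2F)ccn1` and compound 2 `CN(C)CCn1cnnc1-c1cc(Oc2ccc(NC(=O)N/N=C/c3cccc(Cl)c3Cl)cc2F)ccn1`, which differ only in the aryl group on the carbon with a double bond to nitrogen. In a functional assay on MKN-45 cells (Homo sapiens) for cytotoxicity, read by MTT assay, with a stated time of 72 h (a lower number here means a stronger inhibitor, a higher number a weaker inhibitor), compound 1 gives 160 nM, and compound 2 gives 51 nM. That single exchange produced a 3.1-fold lower number from compound 1 to compound 2 (0.50 log units; beyond the scatter), so compound 2 stands as the lowest of the two numbers, with compound 1 as its nearest neighbour.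

Compound 3 `CN(C)CCn1cnnc1-c1cc(Oc2ccc(NC(=O)N/N=C/c3ccc(F)cc3Cl)cc2F)ccn1` takes the next step: 2-chloro-4-fluorophenyl in place of 2,3-dichlorophenyl on a carbon with a double bond to nitrogen. Going by the values given here, the only measured step that bears on it is the one from compound 1 to compound 2, where swapping the pattern of the two chlorines on the same ring moved this assay by a modest amount. Among the compounds with values here, the new change again reshuffles halogens on that ring and also trades one chlorine for fluorine, for which no step exists in this set. A step of comparable size is therefore expected, with no firm direction, and a slight drift upward is the more cautious guess, namely a 1.7-fold higher number from compound 2 to compound 3 (0.22 log units; within the scatter). Compound 3 is estimated to give 85 nM in this assay, within a range from 30 nM to 250 nM.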

Compound 3, half-maximal inhibitory concentration: 870 nM
For compound 3 the middle estimate is 10-fold (1.01 log units) below the measured one, and the stated range ends below it.
By their numbers in this assay, from the lowest: compound 2; then compound 1; then compound 3.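

The aryl group on the carbon with a double bond to nitrogen proves far more sensitive than the two dichlorophenyl compounds alone suggested: 2-chloro-4-fluorophenyl in place of 2,3-dichlorophenyl gives a 17-fold higher number from compound 2 to compound 3 (1.23 log units; beyond the scatter) in this assay and is the largest step in this small set. The same group also compares poorly with 2,6-dichlorophenyl, giving a 5.4-fold higher number from compound 1 to compound 3 (0.74 log units; beyond the scatter), so both dichlorophenyl groups give lower numbers than 2-chloro-4-fluorophenyl and compound 3 is the weakest of the three. Nothing available here accounts for this loss.

Because the exchange from compound 2 to compound 3 removes one chlorine, introduces a fluorine and alters the substitution pattern all at once, the compounds shown cannot separate the effect of the halogen's identity from that of its location on the ring. A 2,4-dichlorophenyl group or a 2-chloro-3-fluorophenyl group would each isolate one of those changes, while a methoxy group or an amine on the ring would show whether this position tolerates anything other than a halogen.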